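This account rests on a few compounds, and the source may have more. Where it says the series, first, only, none or still open, it means among the compounds named here.

Measured so far:
- Compound 1, `Cc1cc(Nc2cc(-c3cccs3)[nH]n2)n2nc(SCc3ccc(Br)cc3)nc2n1`: 3770 nM
- Compound 2, `Cc1cc(Nc2ccn(Cc3ccccc3)n2)n2nc(SCc3ccc(Br)cc3)nc2n1`: 4720 nM
- Compound 3, `Cc1cc(Nc2cc(-c3ccccc3)[nH]n2)n2nc(SCc3cccc(Br)c3)nc2n1`: 4820 nM

In a functional assay on MGC-803 cells (Homo sapiens) for inhibition, read by MTT assay, with a stated time of 72 h (on this read-out lower numbers stand for stronger inhibition and higher numbers for weaker inhibition), compound 3 gives 4820 nM, the highest of the three numbers. Its gap to compound 2 and its gap to compound 1 both lie within the usual scatter of repeated measurements, so the three compounds cannot be told apart on these data; none is stronger or weaker than another with any confidence.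

The next compound, compound 4 `COc1ccc(CSc2nc3nc(C)cc(Nc4cc(-c5ccccc5)[nH]n4)n3n2)cc1`, has not yet been measured in this assay. It differs from compound 3 in one place: 4-methoxyphenyl in place of 3-bromophenyl on a saturated chain carbon bound to a sulfur. For the measured compounds named here, since no step between two measured compounds involves this kind of change, there is nothing to anchor a direction, and the expectation rests only on the three numbers already in hand, all of which sit close together. The expected step, a 1.0-fold higher number from compound 3 to compound 4 (0.02 log units; within the scatter), is no larger than the usual scatter, in no clear direction. Compound 4 is therefore estimated to give 5000 nM in this assay, with a range from 2000 nM to 12000 nM.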

Compound 4, half-maximal inhibitory concentration: 3170 nM
Estimate against measurement, compound 4: 1.6-fold (0.20 log units) above; the measured number falls inside the stated range.
By their numbers in this assay, from the lowest: compounds 4, 1, 2 and 3 (each within the scatter of the next).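

In this assay, replacing 3-bromophenyl with 4-methoxyphenyl on a saturated chain carbon bound to a sulfur gives a 1.5-fold lower number from compound 3 to compound 4 (0.18 log units; within the scatter), so this step does not separate compound 3 from compound 4. For the compounds shown here, it is the first step read at this position, and it shows that exchanging a bromine for a methoxy group, with one hydrogen-bond acceptor entering, and changing the substituent's number on the ring together leave the number within the scatter. Nothing available bears on why the two compounds cannot be told apart.

The two changes arrive together, so the effect of the group and the effect of its place on the ring cannot be read separately. On these data alone, whether an amine, a carboxylic acid or a longer chain at this position would move the number beyond the scatter stays open.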